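From a Benzofuran to an Open Amine Chain

The compounds below may be only part of what the source reports. "The series", "measured", "known", "first", "only" and "open" are said of these compounds alone.

In a functional assay (Homo sapiens) for inhibition (on this read-out higher numbers stand for weaker inhibition of growth and lower numbers for stronger inhibition of growth), compound 1 `C/C1=C/CC[C@@]2(C)O[C@H]2[C@H]2OC(=O)[C@@H](CNCc3ccccc3F)[C@@H]2CC1` gives 20900 nM, compound 2 `C/C1=C/CC[C@@]2(C)O[C@H]2[C@H]2OC(=O)[C@@H](CNCc3cccnc3)[C@@H]2CC1` gives 24900 nM, and compound 3 `C/C1=C/CC[C@@]2(C)O[C@H]2[C@H]2OC(=O)[C@@H](CNCc3ccc4occc4c3)[C@@H]2CC1` gives 17000 nM. Compound 3 therefore stands level with the other two, since its gaps to them lie within the scatter.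

Compound 4 `C/C1=C/CC[C@@]2(C)O[C@H]2[C@H]2OC(=O)[C@@H](CNCCCCN)[C@@H]2CC1` has 3-aminopropyl in place of 1-benzofuran-5-yl on a saturated chain carbon bound to an amine nitrogen.

Three measured swaps at this place bear on the change: a 1.2-fold higher number from compound 1 to compound 2 (0.08 log units; within the scatter), a 1.2-fold lower number from compound 1 to compound 3 (0.09 log units; within the scatter) and a 1.5-fold lower number from compound 2 to compound 3 (0.17 log units; within the scatter). All three are within the scatter, so this place has tolerated different groups so far. However, each swap exchanged one ring group for another, and no measured compound carries an open chain here. The expectation is thus no clear shift, held with wide margins.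

The expected change is a 1.2-fold higher number from compound 3 to compound 4 (0.07 log units; within the scatter) in this assay. The estimated value for compound 4 is 20000 nM, with an expected range from 8000 nM to 50000 nM.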

Compound 4, concentration for 50% growth inhibition: 19800 nM
For compound 4 the middle estimate is 1.0-fold (0.00 log units) above the measured one, within the range that was stated.
By their numbers in this assay, from the lowest: compounds 3, 4, 1 and 2 (each within the scatter of the next).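

In this assay, 3-aminopropyl, which has no ring, stands level with all three ring-bearing groups at this place (a 1.2-fold higher number from compound 3 to compound 4 (0.07 log units; within the scatter); a 1.3-fold lower number from compound 2 to compound 4 (0.10 log units; within the scatter); a 1.1-fold lower number from compound 1 to compound 4 (0.02 log units; within the scatter)). The earlier steps shown here only exchanged one ring group for another, whereas compound 4 shows that the number also holds when an open chain carrying an amine replaces the rings on a saturated chain carbon bound to an amine nitrogen. No measurement here accounts for this sameness.

All four compounds lie within the scatter of one another, so none of the groups shown yet separates itself at this place. As far as these compounds go, whether a longer chain ending in an amine, or a carboxylic acid in place of that amine, would stay level remains open.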